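From piperidin-1-yl to dimethylamino in compound 3

The source may report more compounds than this note shows. Statements on the series, on what has been measured and on what is new or still open speak of the compounds shown alone.

Compound 3 `O=C1c2c[n+]([O-])c3ccccc3c2C(=O)c2c1c1ccccc1n2CCCCN1CCCCC1` gives 610 nM in a toxicity assay on L02 cells (Homo sapiens) for cytotoxicity, read by MTT assay, with a stated time of 72 h; on this read-out lower numbers stand for stronger inhibition and higher numbers for weaker inhibition. Two related compounds help place this number. Compound 2 `O=C1c2c[n+]([O-])c3ccccc3c2C(=O)c2c1c1ccccc1n2Cc1cn(CC(O)CO)nn1` gives 1070 nM, and the gap to the number above is a 1.8-fold lower number from compound 2 to compound 3 (0.24 log units; within the scatter), so these two cannot be told apart. Compound 1 `CN(C)CCCCCn1c2c(c3ccccc31)C(=O)c1c[n+]([O-])c3ccccc3c1C2=O` gives 240 nM, the lowest number of the three, and the gap here is a 2.5-fold higher number from compound 1 to compound 3 (0.41 log units; beyond the scatter).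

Compound 4 `CN(C)CCCCn1c2c(c3ccccc31)C(=O)c1c[n+]([O-])c3ccccc3c1C2=O` has not yet been measured. It differs from compound 3 only at the end of the chain, with dimethylamino in place of piperidin-1-yl on a saturated chain carbon, four bonds along the chain from an aromatic nitrogen.

The best guide is the comparison with compound 1, which also carries dimethylamino. Its chain differs from that of compound 4, however, so the modest 2.5-fold higher number from compound 1 to compound 3 (0.41 log units; beyond the scatter) mixes the end group with the chain and can only partly apply. The other comparison, a 4.5-fold higher number from compound 1 to compound 2 (0.65 log units; beyond the scatter), replaces the whole side chain with a different kind of group and says little about this change.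

In this assay, a small shift towards the number of compound 1 is therefore expected. The estimated step is a 1.8-fold lower number from compound 3 to compound 4 (0.25 log units; within the scatter). Compound 4 is estimated at 340 nM, with an expected range of 150 nM to 750 nM.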

Compound 4, half-maximal inhibitory concentration: 300 nM
For compound 4 the middle estimate is 1.1-fold (0.05 log units) above the measured one, within the range that was stated.
By their numbers in this assay, from the lowest: compounds 1 and 4 (each within the scatter of the next); then compounds 3 and 2 (each within the scatter of the next).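

In this assay, compound 3 and compound 4 carry the same chain and differ only in the end group, so dimethylamino in place of piperidin-1-yl can now be read on its own: it gives a 2.0-fold lower number from compound 3 to compound 4 (0.31 log units; beyond the scatter). This is a modest step, but it shows that the end group alone can move the number at this position, something the earlier comparison with compound 1 could not separate from the chain. Compound 1 and compound 4 both end in dimethylamino and differ only in chain length, and a 1.3-fold higher number from compound 1 to compound 4 (0.10 log units; within the scatter) shows no readable effect of that chain change, while a 3.6-fold lower number from compound 2 to compound 4 (0.55 log units; beyond the scatter) separates the 1-(2,3-dihydroxypropyl)-1H-1,2,3-triazol-4-yl compound from the 3-(dimethylamino)propyl one, a gap that compound 2 and compound 3 did not show beyond the scatter.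

Nothing available here explains why the end group shifts the number. As far as these compounds go, it also remains open where other amines on the same chain, such as pyrrolidin-1-yl, morpholin-4-yl or diethylamino, would fall, and whether a much longer chain ending in dimethylamino would still stay close to compound 4.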